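A few compounds are considered here, and "the series" means these few. Any claim that something is new, unique, unknown or untested is made for them only; others in the source may bear on it.

Compound 1 `CC(C)(CO)/N=c1\c(O)c(O)\c1=N/Cc1ccc(C#N)cc1` is a member of this small series with a hydroxymethyl-bearing group on the double-bonded nitrogen. Among the compounds with values here, in a functional assay for inhibition, with Rattus norvegicus as the target (on this read-out higher numbers stand for weaker inhibition and lower numbers for stronger inhibition), compound 1 gives 21300 nM, the highest of the two numbers recorded; the only other measured member, compound 2 `CCC(C)(C)/N=c1\c(O)c(O)\c1=N/Cc1ccc(SC)cc1`, gives 5600 nM in this assay, a gap noted as beyond the scatter. Compound 2 differs from compound 1 in more than one place, so the two values give no single-change guidance.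

Compound 3 `CCC/N=c1\c(O)c(O)\c1=N/Cc1ccc(C#N)cc1` is the next member to be tested. Within the data shown here, its only difference from compound 1 is propyl in place of 1-(hydroxymethyl)-1-methylethyl on a double-bonded nitrogen.

Among the measured compounds shown here, no measured pair shows this change on its own. Given the standing of compound 1 at 21300 nM, the step is expected to be small, if any, in the direction of a lower number: a 1.4-fold lower number from compound 1 to compound 3 (0.15 log units; within the scatter) is the estimated change. Compound 3 is accordingly expected to give about 15000 nM in this assay, within a range of 4000 nM to 50000 nM.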

Compound 3, half-maximal inhibitory concentration: 21900 nM
For compound 3 the middle estimate is 1.5-fold (0.16 log units) below the measured one, within the range that was stated.
By their numbers in this assay, from the lowest: compound 2; then compounds 1 and 3 (each within the scatter of the next).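

On a double-bonded nitrogen, propyl in place of 1-(hydroxymethyl)-1-methylethyl gives a 1.0-fold higher number from compound 1 to compound 3 (0.01 log units; within the scatter) in this assay, so this single change, the first that can be read in the series, stays within the scatter. With the nitrile-bearing remainder of compound 1 held constant, this place therefore accepts the loss of the hydrogen-bond donor, the hydrogen-bond acceptor and the branched five-heavy-atom group for a three-carbon chain with no shift that can be told from scatter. No supporting measurement is available to explain this flat result.

From the compounds shown here alone, whether an amine, a carboxylic acid or a longer chain such as hexyl on this nitrogen would move the number in this assay remains open. Going by these compounds, compound 2 differs from compound 1 and compound 3 in more than one place, so which of its changes matters also remains open.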